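This account rests on a few compounds, and the source may have more. Where it says the series, first, only, none or still open, it means among the compounds named here.

Measured so far:
compound 2, `Cc1nnc(COc2cnn(C(C)(C)C)c(=O)c2Cl)o1`: > 300 ug/mL
compound 1, `CCn1ncc(OCc2nnc(-c3ccccc3)o2)c(Cl)c1=O`: > 300 ug/mL

Compound 2 stands at a limit of the assay: in a functional assay on the whole organism for inhibition, with Mythimna separata as the target, with a stated time of 5 days (on this read-out higher numbers stand for an effect only at larger amounts of compound and lower numbers for an effect already at smaller amounts), compound 2 gives > 300 ug/mL, a limit and not a number. Compound 1 likewise gives > 300 ug/mL, also a limit. the limit of > 300 ug/mL in this assay, at which 2 of the 2 values shown sit. Compound 3, `CC(C)(C)n1ncc(OCc2nnc(-c3ccc(Cl)cc3)o2)c(Cl)c1=O`, carries 4-chlorophenyl in place of methyl on an aromatic carbon. Within the data shown here, no measured step exists here. Compound 1 carries a phenyl at that same spot and gives > 300 ug/mL, so little change is expected. For compound 3 the expected step of a number no higher from compound 2 to compound 3 (the limit leaves the size open) lies within the scatter, and compound 3 is estimated at 300 ug/mL, between 100 ug/mL and 1000 ug/mL.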

Compound 3, half-maximal effective concentration: 1.9 ug/mL
Beside the measured number, compound 3's estimate is 160-fold (2.20 log units) above it; the measured number lies below the stated range.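

In this assay, 4-chlorophenyl in place of methyl on the aromatic carbon gives an at least 150-fold lower number from compound 2 to compound 3 (2.19 log units; beyond the scatter) and so shows that this position of the five-membered aromatic ring can strongly change the read-out. Among these compounds, compound 3 gives the first real number in the set, while the full size of the step stays unknown, as its starting value is a limit: the limit of > 300 ug/mL in this assay, at which 2 of the 3 values shown sit.

Compound 1 differs from compound 3 in more than one place, so the ring and its chlorine cannot be told apart. On these data alone, how an amine or a longer chain would read at this position stays open.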